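Trifluoromethoxy in Place of Trifluoromethyl on a Weak Scaffold

The compounds below may be only part of what the source reports. "The series", "measured", "known", "first", "only" and "open" are said of these compounds alone.

Compound 1 `Oc1cccc(-c2cc(-c3ccccc3F)cc(-c3cccc(O)c3)n2)c1`: 16000 nM
Compound 2 `Oc1cccc(-c2cc(-c3ccc(C(F)(F)F)cc3)cc(-c3cccc(O)c3)n2)c1`: > 50000 nM, a limit of the assay
Compound 3 `Oc1ccc(-c2cc(-c3ccc(C(F)(F)F)cc3)cc(-c3cccc(O)c3)n2)cc1`: 17300 nM

Three compounds on a shared core were tested in a functional assay on HeLa cells (Homo sapiens) for inhibition; on this read-out higher numbers stand for weaker inhibition and lower numbers for stronger inhibition. Compound 1 gives 16000 nM and compound 3 gives 17300 nM. Compound 2 gives only > 50000 nM, which is a limit of this assay and not a number. Compound 2 therefore stands at the weak end of the set: an at least 3.1-fold higher number from compound 1 to compound 2 (0.49 log units; beyond the scatter), and an at least 2.8-fold lower number from compound 2 to compound 3 (0.46 log units; beyond the scatter), both resting on (the limit of > 50000 nM in this assay, at which 1 of the 3 values shown sits).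

Compound 4 `Oc1cccc(-c2cc(-c3ccc(OC(F)(F)F)cc3)cc(-c3cccc(O)c3)n2)c1` differs from compound 2 by trifluoromethoxy in place of trifluoromethyl on an aromatic carbon. Going by the values given here, neither measured step exchanges these two groups; both steps from compound 2 alter other parts of the molecule, so no measured step bears directly on this change. Compound 4 is therefore expected to show no step beyond the scatter, with an estimate of 50000 nM (range 20000 nM to 125000 nM), so that a number no higher from compound 2 to compound 4 (the limit leaves the size open) is expected.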

Compound 4, half-maximal inhibitory concentration: 18700 nM
Compound 4: the middle estimate sits 2.7-fold (0.43 log units) above what was measured; measured number outside the range, below it.
By their numbers in this assay, from the lowest: compounds 1, 3 and 4 (each within the scatter of the next). At a limit, above all of these: compound 2.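

With the two 3-hydroxyphenyl groups left unchanged, exchanging trifluoromethyl for trifluoromethoxy, para to a large group, is enough on its own to lower the number in this assay: an at least 2.6-fold lower number from compound 2 to compound 4 (0.42 log units; beyond the scatter). Going by these compounds alone, the earlier steps replaced a whole substituted phenyl or moved a hydroxyl, so this is the first sign that the substituent at this position alone matters. Compound 2 gives > 50000 nM, a limit and not a number, so the size of the step stays open: the limit of > 50000 nM in this assay, at which 1 of the 4 values shown sits.

The compounds shown leave open whether methoxy, chlorine or an amine at this place would behave like trifluoromethoxy. They also leave open whether trifluoromethoxy would change the number when combined with the 4-hydroxyphenyl of compound 3.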